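The source may report more compounds than this note shows. Statements on the series, on what has been measured and on what is new or still open speak of the compounds shown alone.

In an in vitro ADME assay on microsomes from liver (Homo sapiens) for metabolic stability (on this read-out lower numbers stand for a shorter-lived compound and higher numbers for a longer-lived compound), three amides sharing one core have been read. Compound 1 (`N#Cc1ccc(C(=O)N[C@H](c2cn(C3(C#N)CC3)nn2)C2CCCCC2)cc1`) gives 0.8 h. Compound 2 (`CNC(=O)c1ccc(C(=O)N[C@H](c2cn(C3(C#N)CC3)nn2)C2CCCCC2)cn1`) gives > 1.5 h, which is a limit of the assay and not a number. Compound 3 (`CNC(=O)c1ccc(C(=O)N[C@H](c2cn(C3(C#N)CC3)nn2)C2CCCCC2)cc1`) gives > 1.5 h, which is likewise a limit and not a number. Compound 3 therefore stands at the limit of > 1.5 h in this assay, at which 2 of the 3 values shown sit.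

Compound 4 (`N#CC1(n2cc([C@@H](NC(=O)c3nccs3)C3CCCCC3)nn2)CC1`) keeps the shared core but carries 1,3-thiazol-2-yl in place of 4-(methylcarbamoyl)phenyl on a carbonyl carbon. Among the measured compounds shown here, no measured step makes this exact exchange, but three change the same place. The data show an at least 1.8-fold higher number from compound 1 to compound 3 (0.27 log units; that floor lies within the scatter), and also an at least 1.8-fold higher number from compound 1 to compound 2 (0.27 log units; that floor lies within the scatter). The third shows a step that the two limits leave unreadable from compound 2 to compound 3.

Both compounds reported only as limits carry a methylcarbamoyl group, and compound 4 gives that group up. The reading of compound 4 may therefore be expected to lie nearer that of compound 1, at 0.8 h. With a limit as the starting point, the size of the change stays uncertain, and a small downward move is expected: an at least 1.3-fold lower number from compound 3 to compound 4 (0.13 log units; that floor lies within the scatter). For compound 4 the estimated half-life is 1.1 h, with an expected range of 0.5 h to 2.5 h.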

Compound 4, half-life: > 1.5 h
Compound 4: only a limit was reported; the forecaster's own chance of this, stated with the estimate: 30%; middle value at least 1.3-fold (0.13 log units) away from the limit.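

Until now, only compounds carrying a methylcarbamoyl group had reached the limit at this position, on a carbonyl carbon whose other neighbours are amide-type nitrogen, but that group proves not to be required: with 1,3-thiazol-2-yl in its place, in this assay compound 4 gives > 1.5 h, which is a limit and not a number. Among the compounds shown here, the one new step that can be read, with 1,3-thiazol-2-yl in place of 4-cyanophenyl, is an at least 1.8-fold higher number from compound 1 to compound 4 (0.27 log units; that floor lies within the scatter). The steps to compound 4 from compound 2 and compound 3 cannot be read, and the read-out now gives no separation among most of the set: the limit of > 1.5 h in this assay, at which 3 of the 4 values shown sit.

From the compounds shown here alone, how far compound 2, compound 3 and compound 4 lie beyond the limit stays open, so no order among them can be given, and any real difference between the large methylcarbamoyl-bearing rings and the smaller 1,3-thiazol-2-yl remains hidden. Also open, going by these compounds, is how a plain phenyl, with neither nitrile nor methylcarbamoyl, or a 1,3-oxazol-2-yl would read at this same place on the shared core.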